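The source may report more compounds than this note shows. Statements on the series, on what has been measured and on what is new or still open speak of the compounds shown alone.

Going by the values given here, in a functional assay on A549 cells (Homo sapiens) for antiproliferative activity, read by MTT assay, with a stated time of 48 h (a lower number here means a stronger inhibitor, a higher number a weaker inhibitor), compound 2 `COc1cc(-c2cccc3nc(-c4ccc(N)cc4)oc23)cc(OC)c1OC` gives 720 nM, the only actual number so far. Compound 1 `COc1cc(-c2cccc3nc(-c4cccc(Cl)c4)oc23)cc(OC)c1OC` reads > 25000 nM, which is a limit of the assay. Compound 3 `COc1cc(-c2cccc3nc(-c4ccco4)oc23)cc(OC)c1OC` changes the same place on the shared core: furan-2-yl in place of 4-aminophenyl on an aromatic carbon. Among the compounds with values here, the one measured step bearing on this, an at least 34-fold lower number from compound 1 to compound 2 (1.54 log units; beyond the scatter), is large, and it shows that the group at this place can matter greatly. With the 4-aminophenyl gone, a sizeable move to a higher number is expected, though furan-2-yl is not the 3-chlorophenyl of compound 1. The expected step is a 6.9-fold higher number from compound 2 to compound 3 (0.84 log units; beyond the scatter). The estimate for compound 3 is 5000 nM, with an expected range of 1000 nM to 25000 nM.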

Compound 3, half-maximal inhibitory concentration: 10300 nM
Beside the measured number, compound 3's estimate is 2.1-fold (0.31 log units) below it; the measured number falls inside the stated range.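

Furan-2-yl does not hold what 4-aminophenyl gives at this place, with a 14-fold higher number from compound 2 to compound 3 (1.16 log units; beyond the scatter) in this assay and no other change. It still stands apart from 3-chlorophenyl, with an at least 2.4-fold lower number from compound 1 to compound 3 (0.38 log units; beyond the scatter) as a second step, so the three groups at this place give graded results and not simply active against inactive. That second step is only a bound, since compound 1 stands at a limit and not a number: the limit of > 25000 nM in this assay, at which 1 of the 3 values shown sits.

As far as these compounds go, whether the gain in compound 2 belongs to its amine or to its six-membered aromatic ring remains open. A plain phenyl or a hydroxyphenyl at this place would separate the two.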